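Phenyl to 2-hydroxyethyl swap on two rearranged cores

A few compounds are considered here, and "the series" means these few. Any claim that something is new, unique, unknown or untested is made for them only; others in the source may bear on it.

Measured compounds:
Compound 1 `CCCCCn1c(-c2ccccc2)nc2c(NCc3ccccc3)ccnc21` — in an assay on isolated protein for inhibition of high affinity 3',5'-cyclic-AMP phosphodiesterase 7A (Homo sapiens), read by cAMP accumulation, with a stated time of 20 min (on this read-out lower numbers stand for stronger inhibition and higher numbers for weaker inhibition), compound 1 gives only a limit, > 200000 nM.
Compound 2 `CCCCCn1c(-c2ccccc2)nc2c(NCCCO)ccnc21` — in this assay compound 2 gives only a limit, > 200000 nM.
Compound 3 `CCCCCn1c(-c2ccccc2)nc2c(NCc3ccccc3)nccc21` — in this assay compound 3 gives only a limit, > 200000 nM.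

Compound 1 and compound 3 are built from the same atoms joined differently; the difference between the two cores is not broken down here. The change from compound 1 to compound 2 is 2-hydroxyethyl in place of phenyl on a saturated chain carbon bound to a nitrogen on an aromatic ring. Its size in this assay is a step that the two limits leave unreadable from compound 1 to compound 2: with both ends sitting at a limit, neither the direction nor the magnitude of this step can be read.

The unmeasured compound 4 `CCCCCn1c(-c2ccccc2)nc2c(NCCCO)nccc21` carries the same kind of change on the core of compound 3: 2-hydroxyethyl in place of phenyl on a saturated chain carbon bound to a nitrogen on an aromatic ring. For the measured compounds named here, the only evidence available on the measured steps is the limit of > 200000 nM in this assay, at which 3 of the 3 values shown sit. Nothing in the three values shows any movement away from the limit on either core.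

The step from compound 3 to compound 4 in this assay is therefore expected to be a step that the limit leaves unreadable from compound 3 to compound 4, resting on (the limit of > 200000 nM in this assay, at which 3 of the 3 values shown sit). Compound 4 is expected to land near 300000 nM, within a range from 100000 nM to 2000000 nM, and most probably the measurement will again return only a limit rather than a number.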

Compound 4, half-maximal inhibitory concentration: > 200000 nM
Compound 4 was reported as a limit; the forecaster's own chance of this, stated with the estimate: 85%; the middle value is on the limit's open side.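

No size or direction can be read for the step from compound 3 to compound 4 in this assay because both values are limits and not numbers: the limit of > 200000 nM in this assay, at which 4 of the 4 values shown sit.

The compounds shown leave open whether any compound on either core, with a benzylamino or a (3-hydroxypropyl)amino group, gives a measurable number in this assay rather than a limit.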